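The source may report more compounds than this note shows. Statements on the series, on what has been measured and on what is new or still open speak of the compounds shown alone.

Values in an in vitro ADME assay on microsomes from liver (Homo sapiens) for metabolic stability; on this read-out higher numbers stand for fast clearance and lower numbers for slow clearance:
- Compound 1 `C#CCN(CC=C)C(=O)[C@@]1(c2ccsc2)C[C@H]1CN`: < 2.6 mL/min/kg, a limit of the assay and not a number
- Compound 2 `C=CCN(CC=C)C(=O)[C@@]1(c2ccsc2)C[C@H]1CN`: 4.7 mL/min/kg
- Compound 3 `C=CCN(CCOC)C(=O)[C@@]1(c2ccsc2)C[C@H]1CN`: not yet measured

In this assay, among the measured compounds shown here, compound 2 gives 4.7 mL/min/kg, the only actual number so far. The change to compound 3 is methoxymethyl in place of vinyl on a saturated chain carbon bound to an amide-type nitrogen. For the measured compounds named here, one measured step bears on it, a different change at that same place: an at least 1.8-fold higher number from compound 1 to compound 2 (0.25 log units; that floor lies within the scatter). Its floor lies within the scatter, so it gives no firm guide to size or direction. No shift beyond the scatter is therefore expected, and the expected step is a 1.0-fold lower number from compound 2 to compound 3 (0.02 log units; within the scatter). The estimate for compound 3 is 4.5 mL/min/kg, with an expected range of 2.3 mL/min/kg to 9 mL/min/kg.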

Compound 3, clearance: < 2.6 mL/min/kg
Compound 3 ended at the assay's limit (the forecaster's own chance of this, stated with the estimate: 20%); middle value at least 1.7-fold (0.23 log units) from the limit.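

In this assay, methoxymethyl in place of vinyl on a saturated chain carbon bound to an amide-type nitrogen gives an at least 1.8-fold lower number from compound 2 to compound 3 (0.25 log units; that floor lies within the scatter). Compound 3 reads < 2.6 mL/min/kg, which is a limit of the assay and not a number. So this place can carry a saturated chain with an ether oxygen, as well as the alkyne chain of compound 1, and still read at the limit: the limit of < 2.6 mL/min/kg in this assay, at which 2 of the 3 values shown sit.

The step between the two limit compounds, compound 1 and compound 3, cannot be read. From the compounds shown here alone, how an amine, a carboxylic acid or a longer ether chain would read at this place remains open.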